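The source may report more compounds than this note shows. Statements on the series, on what has been measured and on what is new or still open speak of the compounds shown alone.

Going by the values given here, in a functional assay on HeLa cells (Homo sapiens) for inhibition, with a stated time of 72 h (on this read-out higher numbers stand for weaker inhibition and lower numbers for stronger inhibition), compound 1 `NC1CCC(Nc2nc(NCc3ccc(-c4ccco4)cc3)c3ncn(C4CCCC4)c3n2)CC1` gives 71 nM and compound 2 `NC1CCC(Nc2nc(NCc3ccc(-c4ccccc4)nc3)c3ncn(C4CCCC4)c3n2)CC1` gives 114 nM, so compound 2 lies within the scatter of the only other measured value. Compound 3 `NC1CCC(Nc2nc(NCc3ccc(-c4ccco4)nc3)c3ncn(C4CCCC4)c3n2)CC1` carries furan-2-yl in place of phenyl on an aromatic carbon of compound 2: furan-2-yl in place of phenyl on an aromatic carbon. Among the compounds with values here, the one measured step bearing on this is a 1.6-fold higher number from compound 1 to compound 2 (0.21 log units; within the scatter), where 6-phenylpyridin-3-yl replaces 4-(furan-2-yl)phenyl. That step is small, so no change beyond the scatter is expected in this assay. The expected step is a 1.3-fold lower number from compound 2 to compound 3 (0.10 log units; within the scatter). For compound 3 the estimated value is 90 nM, with an expected range of 35 nM to 230 nM.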

Compound 3, half-maximal inhibitory concentration: 30 nM
Beside the measured number, compound 3's estimate is 3.0-fold (0.48 log units) above it; measured number below the stated range.
By their numbers in this assay, from the lowest: compound 3; then compounds 1 and 2 (each within the scatter of the next).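

In this assay, the group on the carbon next to the ring nitrogen now matters: furan-2-yl in place of phenyl gives a 3.8-fold lower number from compound 2 to compound 3 (0.58 log units; beyond the scatter), whereas the earlier pair stayed within the scatter. With furan-2-yl held constant, the ring nitrogen also counts: 6-(furan-2-yl)pyridin-3-yl in place of 4-(furan-2-yl)phenyl gives a 2.4-fold lower number from compound 1 to compound 3 (0.37 log units; beyond the scatter). Nothing at hand accounts for either step.

From the compounds shown here alone, whether this gain is specific to furan-2-yl remains open. Thiophen-2-yl or a methyl group on the same carbon would show how far it extends.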